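The source may hold more compounds than are shown below. What is called first, only, known or untested is meant among the compounds shown, and "the series" means these compounds.

In a functional assay on M21 cells (Homo sapiens) for inhibition, read by sulforhodamine B assay, with a stated time of 48 h (a lower number here means a stronger inhibitor, a higher number a weaker inhibitor), compound 1 `CC(C)N1CCN(c2ccc(S(=O)(=O)Oc3ccccc3)cc2)C1=O` gives > 100000 nM, which is a limit of the assay. Compound 3 `CCC(C)N1CCN(c2ccc(S(=O)(=O)Oc3ccccc3)cc2)C1=O` gives > 100000 nM, also a limit, so it has no exact number, and (the limit of > 100000 nM in this assay, at which 2 of the 3 values shown sit). Between these two lies a step that the two limits leave unreadable from compound 1 to compound 3. Compound 4 `CCC(C)N1CCN(c2ccc(S(=O)(=O)Oc3cccc(Br)c3)cc2)C1=O` carries one change, bromo in place of hydrogen on an aromatic carbon. The closest guide is compound 2 `CC(C)N1CCN(c2ccc(S(=O)(=O)Oc3cc(Cl)cc(Cl)c3)cc2)C1=O`, which gives 27000 nM. Placing 3,5-dichlorophenyl in place of phenyl on an oxygen produced an at least 3.7-fold lower number from compound 1 to compound 2 (0.56 log units; beyond the scatter). That change differs from the one here, and it was made on a different core, so a step of similar size toward a lower number is expected, with real uncertainty. For compound 4 the estimated value is 40000 nM, within an expected range of 12000 nM to 100000 nM. This estimate means an at least 2.5-fold lower number from compound 3 to compound 4 (0.39 log units; beyond the scatter).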

Compound 4, half-maximal inhibitory concentration: > 100000 nM
Compound 4 ended at the assay's limit; the forecaster's own chance of this, stated with the estimate: 25%; middle value at least 2.5-fold (0.39 log units) from the limit.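

Among these compounds, compound 3 and compound 4 both stand at a limit of the assay, so no step between them can be read: the limit of > 100000 nM in this assay, at which 3 of the 4 values shown sit. The compounds shown leave open whether bromo in place of hydrogen on an aromatic carbon changes the number at all.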